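Benzylsulfanyl in place of amino: a small expected step

The source may hold more compounds than are shown below. What is called first, only, known or untested is meant among the compounds shown, and "the series" means these compounds.

In a functional assay on MCF7 cells (Homo sapiens) for antiproliferative activity, read by MTT assay, with a stated time of 48 h (on this read-out lower numbers stand for stronger inhibition and higher numbers for weaker inhibition), compound 1 (`Cc1ccc(-c2nc3ccc(Cl)cc3c(=S)[nH]2)cc1`) gives 3.35 ug/mL while compound 2 (`Cc1ccc(-c2nc(N)c3cc(Cl)ccc3n2)cc1`) gives 3.76 ug/mL and so stands within the scatter of compound 1. Compound 3 (`Cc1ccc(-c2nc(SCc3ccccc3)c3cc(Cl)ccc3n2)cc1`) carries benzylsulfanyl in place of amino on an aromatic carbon. Among the measured compounds shown here, no measured step bears on this change, and no move beyond the scatter is expected in this assay for it. The estimated step is a 1.1-fold lower number from compound 2 to compound 3 (0.03 log units; within the scatter) and is expected to stay within the scatter. For compound 3 the estimated value is 3.5 ug/mL with an expected range from 1.2 ug/mL to 10 ug/mL on this read-out.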

Compound 3, half-maximal inhibitory concentration: 9.66 ug/mL
Compound 3: the middle estimate sits 2.8-fold (0.44 log units) below what was measured, within the range that was stated.
By their numbers in this assay, from the lowest: compounds 1 and 2 (each within the scatter of the next); then compound 3.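

In this assay, the change on the aromatic carbon next to the ring nitrogen gives a 2.6-fold higher number from compound 2 to compound 3 (0.41 log units; beyond the scatter), so this position does not tolerate every replacement of amino without a loss. With amino and benzylsulfanyl differing in several ways at once, this single step cannot show which difference matters. Nothing shown here gives a cause for the step. Going by these compounds, it remains open whether a benzylamino group, which keeps the nitrogen link and adds the ring, or a methylsulfanyl group, which keeps the sulfur without the ring, would stay with compound 2 or move with compound 3.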